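Replacing an ester with an amine in a rat cytotoxicity assay

The source may hold more compounds than are shown below. What is called first, only, known or untested is meant among the compounds shown, and "the series" means these compounds.

Compound 2 `CCOC(=O)CN1CCC2(N3CCCCC3)CC(c3ccc(Cl)cc3)C1C(c1ccc(Cl)cc1)C2` was measured in an ADME assay on L6 cells (Rattus norvegicus) for cytotoxicity, read by resazurin assay, with a stated time of 72 h (a lower number here means a stronger inhibitor, a higher number a weaker inhibitor), and gave 13100 nM. This is the highest of the two numbers gathered so far, the other belonging to compound 1 `NCCN1CCC2(N3CCCC3)CC(c3ccc(Cl)cc3)C1C(c1ccc(Cl)cc1)C2`, which in this assay gave 4650 nM, a gap beyond the usual scatter. The next compound, compound 3 `NCCN1CCC2(N3CCCCC3)CC(c3ccc(Cl)cc3)C1C(c1ccc(Cl)cc1)C2`, has not yet been measured. Its structure differs from compound 2 in one place: aminomethyl in place of ethoxycarbonyl on a saturated chain carbon bound to an amine nitrogen in a ring. Compound 1 already carries the same 2-aminoethyl group on its ring nitrogen, so its value of 4650 nM is the closest guide available, and the account expects the step of a 2.4-fold lower number from compound 2 to compound 3 (0.38 log units; beyond the scatter) to run downward by a moderate amount, toward stronger cytotoxicity. On that basis compound 3 is estimated to give about 5500 nM in this assay, with a plausible range from 2500 nM to 12000 nM.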

Compound 3, half-maximal inhibitory concentration: 3370 nM
Compound 3: middle estimate off by 1.6-fold (0.21 log units), on the high side; the measured number falls inside the stated range.
By their numbers in this assay, from the lowest: compounds 3 and 1 (each within the scatter of the next); then compound 2.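

In this assay, aminomethyl in place of ethoxycarbonyl on a saturated chain carbon bound to an amine nitrogen in a ring can now be read as a single change (a 3.9-fold lower number from compound 2 to compound 3 (0.59 log units; beyond the scatter)), which the earlier pair, differing in two places, did not allow. With the 2-aminoethyl group held fixed, piperidin-1-yl in place of pyrrolidin-1-yl on a saturated ring carbon gives a step that stays within the scatter (a 1.4-fold lower number from compound 1 to compound 3 (0.14 log units; within the scatter)), so among these compounds only the change at the chain separates the numbers. Nothing available explains why the chain change gives this step.

The compounds shown leave open where a carboxylic acid, an amide or a longer chain ending in an amine would fall at this position. They also leave open whether the step from ester to amine is the same size with pyrrolidin-1-yl on the ring carbon.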